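Pyrrolidinylmethyl in place of pentan-3-yl on the ring nitrogen

The source may hold more compounds than are shown below. What is called first, only, known or untested is meant among the compounds shown, and "the series" means these compounds.

Measured compounds:
compound 1, `CCCCN(CCCC)c1cc(C)nc2c(-c3ccc(Cl)cc3Cl)nn(C)c12`, 0.62 nM
compound 2, `CCCCN(c1cc(C)nc2c(-c3ccc(Cl)cc3Cl)nn(C)c12)C(CC)CC`, 7 nM

Both compounds share a core and differ only in the group on the nitrogen attached to the aromatic ring. In an assay on HEK293 cells for displacement of a labelled ligand from corticotropin-releasing factor receptor 1 (Homo sapiens) (a lower number here means a stronger inhibitor, a higher number a weaker inhibitor), compound 1 gives 0.62 nM, while compound 2 gives 7 nM, and the step from one to the other is an 11-fold higher number from compound 1 to compound 2 (1.05 log units; beyond the scatter). Within the data shown here, compound 2 therefore stands with the higher of the two numbers so far, separated from compound 1 by a gap that lies beyond the scatter.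

Compound 3, `CCCCN(CC1CCCN1C)c1cc(C)nc2c(-c3ccc(Cl)cc3Cl)nn(C)c12`, is not yet measured. Relative to compound 2 the change is (1-methylpyrrolidin-2-yl)methyl in place of pentan-3-yl on a nitrogen on an aromatic ring. Among the measured compounds shown here, the only measured step that bears on this position is an 11-fold higher number from compound 1 to compound 2 (1.05 log units; beyond the scatter), which shows that the shape of the chain on this nitrogen matters a great deal. The new group returns to a chain that is unbranched at its first carbon, but carries a ring further along, so a number somewhere between those of compound 1 and compound 2 is expected. The estimated step is a 2.3-fold lower number from compound 2 to compound 3 (0.37 log units; beyond the scatter). For compound 3 the expected value in this assay is 3 nM, with a range from 0.6 nM to 15 nM.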

Compound 3, inhibition constant: 380 nM
Beside the measured number, compound 3's estimate is 130-fold (2.10 log units) below it; the measured number lies above the stated range.
By their numbers in this assay, from the lowest: compound 1; then compound 2; then compound 3.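

On the nitrogen on the aromatic ring, (1-methylpyrrolidin-2-yl)methyl is the least favourable group so far in this assay, and it weakens binding well beyond the branched pentan-3-yl (a 54-fold higher number from compound 2 to compound 3 (1.73 log units; beyond the scatter)) as well as the butyl of the parent (a 610-fold higher number from compound 1 to compound 3 (2.79 log units; beyond the scatter)). The earlier step had shown only that replacing butyl with pentan-3-yl raises the number, whereas this result shows that a group with a chain carbon, not a branch point, bound to that nitrogen can still give a far higher number than either. Nothing available here accounts for the size of this rise.

The compounds shown leave open whether the higher number follows the five-membered ring itself or the nitrogen within it, a question that a cyclopentylmethyl group, holding carbon in place of that nitrogen, would address. They also leave open how the same group lacking the methyl on its ring nitrogen, or an open-chain amine such as dimethylaminoethyl, would compare with compound 3 on this nitrogen.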